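The source may report more compounds than this note shows. Statements on the series, on what has been measured and on what is new or still open speak of the compounds shown alone.

In a physicochemical assay for solubility, at pH 7 (a higher number here means a more soluble compound, a lower number a less soluble compound), three compounds built on one shared core have been measured. Compound 1 `CN1CCC(C(=O)N2Cc3c(NC(=O)c4ccc5ccccc5c4)n[nH]c3C2(C)C)CC1`, with naphthalen-2-yl on a carbonyl carbon, gives 219000 nM. Compound 2 `CN1CCC(C(=O)N2Cc3c(NC(=O)c4ccc(F)c(F)c4)n[nH]c3C2(C)C)CC1`, with 3,4-difluorophenyl in that place, reports only a limit, > 225000 nM. Compound 3 `CN1CCC(C(=O)N2Cc3c(NC(=O)c4ccco4)n[nH]c3C2(C)C)CC1`, with furan-2-yl there, also reports only a limit, > 225000 nM. Compound 3 therefore has no exact number and stands at the limit of > 225000 nM in this assay, at which 2 of the 3 values shown sit.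

Compound 4 `CN1CCC(C(=O)N2Cc3c(NC(=O)c4cccc(F)c4)n[nH]c3C2(C)C)CC1` has 3-fluorophenyl in place of furan-2-yl on a carbonyl carbon, with the rest of the structure unchanged: 3-fluorophenyl in place of furan-2-yl on a carbonyl carbon. The closest measured comparison, which also swaps furan-2-yl for a fluorinated phenyl group, offers little, as it is a step that the two limits leave unreadable from compound 2 to compound 3. The two other measured steps on this carbonyl carbon are an at least 1.0-fold higher number from compound 1 to compound 2 (0.01 log units; that floor lies within the scatter) and an at least 1.0-fold higher number from compound 1 to compound 3 (0.01 log units; that floor lies within the scatter). Neither gives evidence of a change beyond the scatter, so no such change is expected here, in either direction, and compound 4 may well report only a limit too. The expected step is a step that the limit leaves unreadable from compound 3 to compound 4. For compound 4, the estimated value is 230000 nM, with an expected range from 170000 nM to 300000 nM.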

Compound 4, solubility: > 225000 nM
Compound 4 ended at the assay's limit; the forecaster's own chance of this, stated with the estimate: 75%; the middle value lies beyond the limit too.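

In this assay, 3-fluorophenyl on this carbonyl carbon meets the same limit as the two earlier smaller groups, which leaves one limit covering most of the series: the limit of > 225000 nM in this assay, at which 3 of the 4 values shown sit. Replacing naphthalen-2-yl with 3-fluorophenyl gives an at least 1.0-fold higher number from compound 1 to compound 4 (0.01 log units; that floor lies within the scatter), so this new step, like the two earlier steps from compound 1, shows no change beyond the scatter. The steps among compound 2, compound 3 and compound 4 cannot be read, since each of these compounds reports only a limit, and that includes the removal of one fluoro group on the aromatic ring.

As far as these compounds go, how these three compounds truly rank, and how far their solubility reaches, stays open, since a limit gives no number to compare. Also open, from the compounds shown here alone, is whether any group on this carbonyl carbon can move the read-out down beyond the scatter, for example a long alkyl chain, a biphenyl group or a carboxylic acid on the aromatic ring.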